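The source may report more compounds than this note shows. Statements on the series, on what has been measured and on what is new or still open speak of the compounds shown alone.

Working notes on the series, read in a functional assay on CCRF-CEM cells (Homo sapiens) for antiproliferative activity, read by cell counting, with a stated time of 2 days; a higher number here means a weaker inhibitor, a lower number a stronger inhibitor. Of the compounds shown here, two have numbers so far. Compound 1 `COc1cc(C(=O)c2sc(Nc3ccc(F)cc3)nc2N)cc(OC)c1OC` gives 400 nM, and compound 2 `COc1ccc(Nc2nc(N)c(C(=O)c3ccc(OC)c(OC)c3)s2)cc1` gives 10 nM. Compound 2 therefore holds the lower of the two numbers, and the gap to compound 1 lies beyond the scatter.

The next compound is compound 3 `COc1ccc(Nc2nc(N)c(C(=O)c3cc(OC)c(OC)c(OC)c3)s2)cc1`. It differs from compound 2 by a methoxy in place of hydrogen on an aromatic carbon, ortho to a methoxy group: methoxy in place of hydrogen on an aromatic carbon.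

Going by the values given here, no two measured compounds differ in one place only, so the series offers no direct precedent for this change. The expectation starts from compound 2 at 10 nM, and the upper side is left wide with compound 1 at 400 nM in view. A small move towards weaker inhibition in this assay is expected, possibly no larger than the scatter. The expected change is a 2.5-fold higher number from compound 2 to compound 3 (0.40 log units; beyond the scatter). For compound 3 the estimated value is 25 nM, with an expected range of 5 nM to 120 nM.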

Compound 3, half-maximal inhibitory concentration: 1100 nM
For compound 3 the middle estimate is 44-fold (1.64 log units) below the measured one; the whole stated range lies below it.
By their numbers in this assay, from the lowest: compound 2; then compound 1; then compound 3.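

In this assay, methoxy in place of hydrogen on an aromatic carbon, ortho to a methoxy group, gives a 110-fold higher number from compound 2 to compound 3 (2.04 log units; beyond the scatter), so this carbon is far from indifferent to substitution, and this single added group produces the larger of the two steps now available. The other step, methoxy in place of fluoro on an aromatic carbon, gives a 2.8-fold higher number from compound 1 to compound 3 (0.44 log units; beyond the scatter) and is modest by comparison, showing that with the added methoxy in place, this second change moves the number much less. Nothing measured on these compounds accounts for the size of either step.

The compounds shown hold only hydrogen or methoxy at the sensitive carbon, so it remains open whether a fluoro, a hydroxy or an ethoxy group there would be tolerated or would give a similar rise in the number. On these data alone, it also remains open whether methoxy in place of fluoro gives a step of the same size when that carbon carries hydrogen, as in compound 2.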